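This account rests on a few compounds, and the source may have more. Where it says the series, first, only, none or still open, it means among the compounds named here.

Working notes on the series. Among the compounds with values here, in a functional assay on NALM-6 cells (Homo sapiens) for cytotoxicity, with a stated time of 72 h (a higher number here means that more compound is needed for the effect, a lower number that less compound is needed), compound 1 `C=C[C@@](C)(/C=C/c1ccc(O)c(C=O)c1)CCC=C(C)C` gives 11200 nM, the only number so far. Compound 2 `C=C[C@@](C)(/C=C/c1ccc(O)c(/C=C/C(=O)O)c1)CCC=C(C)C` reaches only a limit, > 43400 nM. Going by these compounds, compound 3 `C=C[C@@](C)(/C=C/c1ccc(O)c(/C=C/C(N)=O)c1)CCC=C(C)C` also reaches only a limit, > 43400 nM, so its true position is unknown, and it shares this position with compound 2: the limit of > 43400 nM in this assay, at which 2 of the 3 values shown sit.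

The next change leads to compound 4 `C=C[C@@](C)(/C=C/c1ccc(O)c(/C=C(\C)C(=O)OCC)c1)CCC=C(C)C`. Here 2-(ethoxycarbonyl)prop-1-en-1-yl replaces 2-carbamoylethenyl on an aromatic carbon, ortho to a hydroxy group: 2-(ethoxycarbonyl)prop-1-en-1-yl in place of 2-carbamoylethenyl on an aromatic carbon.

Within the data shown here, two measured steps bear on this position. Replacing formyl with 2-carboxyethenyl gives an at least 3.8-fold higher number from compound 1 to compound 2 (0.58 log units; beyond the scatter). Replacing formyl with 2-carbamoylethenyl gives an at least 3.8-fold higher number from compound 1 to compound 3 (0.58 log units; beyond the scatter). Both are at least modest and point the same way. Amino in place of hydroxy on the carbonyl carbon gives a step that the two limits leave unreadable from compound 2 to compound 3, so that swap offers no guide. Among the measured compounds shown here, no measured step covers the entering group itself.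

Compound 4 is therefore expected to stay nearer the limit of compound 3 than the value of compound 1, and it may also return only a limit. The expected change is small and towards a lower number: an at least 1.5-fold lower number from compound 3 to compound 4 (0.19 log units; that floor lies within the scatter). For compound 4, the estimate is 28000 nM, with an expected range of 10000 nM to 60000 nM.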

Compound 4, half-maximal effective concentration: > 7500 nM
Compound 4 was reported as a limit; the forecaster's own chance of this, stated with the estimate: 50%; the middle value lies beyond the limit too.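

Compound 4 returns only a limit, > 7500 nM. Its steps from compound 1, compound 2 and compound 3 therefore cannot be read, and no new comparison follows. The compounds shown leave open where compound 4 truly stands, and whether 2-(ethoxycarbonyl)prop-1-en-1-yl in place of formyl shifts the number from compound 1 at all.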